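The compounds below may be only part of what the source reports. "The series", "measured", "known", "first", "only" and "open" are said of these compounds alone.

The measured compounds, all read in a functional assay on NCI-H460 cells (Homo sapiens) for cytotoxicity, read by MTT assay; on this read-out higher numbers stand for weaker inhibition and lower numbers for stronger inhibition:
Compound 1 `Cc1ccc(Nc2nc(C)c(C(=O)/C=C/c3ccc(Cl)cc3)s2)cc1` gives > 25000 nM, which is a limit of the assay and not a number.
Compound 2 `COc1cccc(/C=C/C(=O)c2sc(Nc3ccc(Cl)c(Cl)c3)nc2C)c1` gives 20100 nM.
Compound 3 `Cc1nc(Nc2cccc(Cl)c2)sc1C(=O)/C=C/c1ccc(Cl)cc1` gives > 25000 nM, again a limit and not a number.

Among the measured compounds shown here, compound 2 therefore stands as the only compound with an actual number; the other two values are the limit of > 25000 nM in this assay, at which 2 of the 3 values shown sit. For the measured compounds named here, the one step that can be drawn between measured compounds, a step that the two limits leave unreadable from compound 1 to compound 3, runs from one limit to another and cannot be read.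

Compound 4 `COc1ccc(/C=C/C(=O)c2sc(Nc3ccc(Cl)c(Cl)c3)nc2C)cc1` keeps the whole of compound 2 except at one place: 4-methoxyphenyl in place of 3-methoxyphenyl on a double-bonded chain carbon bound to a double-bonded chain carbon. Going by the values given here, no measured step touches this part of the molecule, so the measured compounds say nothing about how large this change is or which way it goes. The expected step is a 1.0-fold lower number from compound 2 to compound 4 (0.00 log units; within the scatter), meaning no change beyond the usual scatter is expected. Compound 4 is expected to give about 20000 nM in this assay, within 8000 nM to 50000 nM, with a real chance that only a limit is reported.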

Compound 4, half-maximal inhibitory concentration: > 25000 nM
Compound 4: only a limit was reported; the forecaster's own chance of this, stated with the estimate: 45%; middle value at least 1.2-fold (0.09 log units) from the limit.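

Among the compounds shown here, replacing 3-methoxyphenyl with 4-methoxyphenyl is the first measured change at this place on the double-bonded chain carbon, and in this assay it gives an at least 1.2-fold higher number from compound 2 to compound 4 (0.09 log units; that floor lies within the scatter). Compound 4 gives > 25000 nM, which is a limit and not a number, so this step has a floor but no upper end: the change may be negligible or large. Moving the methoxy group therefore yields no number that can be set beside that of compound 2, and the set remains gathered at one ceiling: the limit of > 25000 nM in this assay, at which 3 of the 4 values shown sit.

From the compounds shown here alone, it remains open whether another group at this place, such as a dimethylamino group or a carboxylic acid on the phenyl ring in place of methoxy, would give a clearly lower number. Going by these compounds, it is also open whether the methoxy shift would behave the same way with a different group on the nitrogen.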